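The compounds below may be only part of what the source reports. "The series", "measured", "known", "first", "only" and "open" are said of these compounds alone.

Measured compounds:
compound 1 `C[C@@H](Nc1c(C(=O)NCc2ccc(F)cc2)nc(Br)c2cccnc12)c1ccccc1` — > 20000 nM in a functional assay on HCT-116 cells (Homo sapiens) for cytotoxicity, read by MTT assay, with a stated time of 72 h; on this read-out higher numbers stand for weaker inhibition and lower numbers for stronger inhibition
compound 2 `C[C@@H](CO)Nc1nc(C(=O)NCc2ccc(F)cc2)c(O)c2ncccc12` — "not determined" (no result reported) in this assay

Compound 1 stands at the edge of what the assay reports: its value is a limit, not a number, and it marks (the limit of > 20000 nM in this assay, at which 1 of the 2 values shown sits). For the measured compounds named here, for compound 2 no result was recorded, so no comparison between the two measured compounds can be drawn, and no step between measured compounds is available.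

Compound 3 `CNCCCNc1c(C(=O)NCc2ccc(F)cc2)nc(Br)c2cccnc12` differs from compound 1 in one place: 3-(methylamino)propyl in place of 1-phenylethyl on a nitrogen on an aromatic ring. With compound 1 itself resting at a limit, the step cannot be anchored on both sides, and the account rests on that single limit alone.

Compound 3 is expected to remain weak in this assay, with an estimated value of 12000 nM, ranging from 3000 nM to 40000 nM. This expectation corresponds to a step of an at least 1.6-fold lower number from compound 1 to compound 3 (0.22 log units; that floor lies within the scatter), which, measured against a limit, may amount to nothing beyond the scatter.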

Compound 3, half-maximal inhibitory concentration: 9000 nM
Beside the measured number, compound 3's estimate is 1.3-fold (0.12 log units) above it, within the range that was stated.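

Putting 3-(methylamino)propyl in place of 1-phenylethyl on this nitrogen moves the reading in this assay from a limit to a number, with an at least 2.2-fold lower number from compound 1 to compound 3 (0.34 log units; beyond the scatter). At this place, then, neither the six-membered aromatic ring nor the defined stereocentre of 1-phenylethyl is needed for a measurable value, and an open chain carrying a nitrogen gives one. Compound 1 rests on a limit, not a number, so the step is only a floor and its full size remains unknown: the limit of > 20000 nM in this assay, at which 1 of the 3 values shown sits.

For the compounds shown here, the single change swaps ring for chain and adds a nitrogen at once, so it does not tell which of these matters. As far as these compounds go, a plain propyl chain, a longer chain ending in the same methylamino group, or a dimethylamino end would separate these, and whether any of them goes further remains open.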